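This account rests on a few compounds, and the source may have more. Where it says the series, first, only, none or still open, it means among the compounds named here.

Going by the values given here, in a functional assay on K562 cells (Homo sapiens) for antiproliferative activity, read by MTT assay, with a stated time of 5 days (on this read-out higher numbers stand for weaker inhibition and lower numbers for stronger inhibition), two compounds have numbers so far. Compound 1 (`COc1ccc(C(=Cc2ccc(OC)c([N+](=O)[O-])c2)C(=O)c2cc(OC)c(OC)c(OC)c2)cc1`) gives 2660000 nM. Compound 2 (`COc1ccc(/C=C(/C(=O)c2cc(OC)c(OC)c(OC)c2)c2ccccc2O)cc1O`) gives 49000 nM, the lower of the two numbers, and the gap to compound 1 lies beyond the scatter. Compound 3 (`COc1ccc(/C=C(/C(=O)c2cc(OC)c(OC)c(OC)c2)c2ccccc2O)cc1`) has not yet been measured. It differs from compound 2 in one place: hydrogen in place of hydroxy on an aromatic carbon, with hydrogen in place of hydroxy on an aromatic carbon, ortho to a methoxy group, so that 3-hydroxy-4-methoxyphenyl becomes 4-methoxyphenyl. Among the compounds with values here, no measured pair differs in one place only, so nothing calibrates this change directly and the expectation is loosely grounded. In this assay a moderate upward move towards weaker inhibition is expected: a 2.0-fold higher number from compound 2 to compound 3 (0.31 log units; beyond the scatter). The estimate for compound 3 is 100000 nM, with an expected range of 20000 nM to 500000 nM.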

Compound 3, half-maximal inhibitory concentration: 370000 nM
The estimate for compound 3 lay 3.7-fold (0.57 log units) below the measured number, and the stated range covers the measured number.
By their numbers in this assay, from the lowest: compound 2; then compound 3; then compound 1.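

In this assay, going by these compounds alone, the change from 3-hydroxy-4-methoxyphenyl to 4-methoxyphenyl gives a 7.6-fold higher number from compound 2 to compound 3 (0.88 log units; beyond the scatter) and is the first one-place step. The position on the aromatic carbon ortho to a methoxy group is therefore not indifferent here: with only the hydroxy exchanged for hydrogen, the number moves towards weaker inhibition by more than the scatter. No measurement at hand bears on why the number rises with this exchange.

This single step cannot show whether the hydroxy itself is needed at this position or whether another group, such as an amine or a fluorine, would keep the number of compound 2. It also leaves open whether the same exchange would give a step of similar size on a different core.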